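An Allene Replaces an Alkyne on the Ether Chain

A few compounds are considered here, and "the series" means these few. Any claim that something is new, unique, unknown or untested is made for them only; others in the source may bear on it.

In a functional assay on aorta (Rattus norvegicus, strain Sprague-Dawley) for inhibition (a higher number here means that more compound is needed for the effect, a lower number that less compound is needed), compound 3 `C#CCOc1cc2c(c3c1C[C@@H]1[C@@H](C)CO[C@]1(C)O3)C[C@@H]1[C@@H](C)CO[C@]1(C)O2` gives 23000 nM and compound 1 `CCCOc1cc2c(c3c1C[C@@H]1[C@@H](C)CO[C@]1(C)O3)C[C@@H]1[C@@H](C)CO[C@]1(C)O2` gives 43000 nM so the two stand level within the scatter. Compound 2 `CCCCCCOc1cc2c(c3c1C[C@@H]1[C@@H](C)CO[C@]1(C)O3)C[C@@H]1[C@@H](C)CO[C@]1(C)O2` reads > 200000 nM as a limit of the assay, not a number. Compound 4 `C=C=CCOc1cc2c(c3c1C[C@@H]1[C@@H](C)CO[C@]1(C)O3)C[C@@H]1[C@@H](C)CO[C@]1(C)O2` carries propa-1,2-dien-1-yl in place of ethynyl, a change counted as propa-1,2-dien-1-yl in place of ethynyl on a saturated chain carbon bound to an oxygen on an aromatic ring on the chain. For the measured compounds named here, two measured steps bear on it: a 1.9-fold lower number from compound 1 to compound 3 (0.27 log units; within the scatter) stayed small, while the longer chain gave an at least 4.6-fold higher number from compound 1 to compound 2 (0.66 log units; beyond the scatter) upward. In this assay a slight rise is therefore expected, with no step beyond the scatter. The estimated step is a 1.3-fold higher number from compound 3 to compound 4 (0.12 log units; within the scatter) for this change. Compound 4 is expected at 30000 nM within a range of 12000 nM to 80000 nM as estimated.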

Compound 4, half-maximal effective concentration: 12000 nM
Compound 4: the middle estimate sits 2.5-fold (0.40 log units) above what was measured, and the stated range covers the measured number.
By their numbers in this assay, from the lowest: compounds 4, 3 and 1 (each within the scatter of the next, the first and the last beyond it). At a limit, above all of these: compound 2.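

In this assay, the step of a 1.9-fold lower number from compound 3 to compound 4 (0.28 log units; within the scatter) stays small, so a chain ending in propa-1,2-dien-1-yl reads level with one ending in ethynyl. Against the saturated chain, the step of a 3.6-fold lower number from compound 1 to compound 4 (0.55 log units; beyond the scatter) clears the scatter, which compound 3 did not do. The step of an at least 16-fold lower number from compound 2 to compound 4 (1.22 log units; beyond the scatter) is only a bound, since its starting value is a limit: the limit of > 200000 nM in this assay, at which 1 of the 4 values shown sits.

As far as these compounds go, how far this difference rests on the unsaturated chain end rather than on chain length stays open. So does what a longer allene chain, a nitrile or an amine at the chain end would give.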